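A few compounds are considered here, and "the series" means these few. Any claim that something is new, unique, unknown or untested is made for them only; others in the source may bear on it.

The values below come from a functional assay on DU-145 cells (Homo sapiens) for cytotoxicity, read by ELISA, with a stated time of 2 days (a higher number here means a weaker inhibitor, a lower number a stronger inhibitor), and stand as follows:
- compound 1 (`Oc1ccccc1-c1cc(-c2ccccc2)nc(-c2ccco2)c1`) gives 4900 nM
- compound 2 (`Oc1cccc(-c2cc(-c3ccccc3)nc(-c3cccs3)c2)c1`) gives 19700 nM
- compound 3 (`Oc1cccc(-c2cc(-c3ccccc3)nc(-c3ccsc3)c2)c1`) gives 11700 nM

Compound 3 at 11700 nM lies within the scatter of compound 2 and higher, beyond the scatter, than compound 1. Compound 4 (`Oc1cccc(-c2cc(-c3ccccc3)nc(-c3ccco3)c2)c1`) carries furan-2-yl in place of thiophen-3-yl on an aromatic carbon of the shared core. Among the compounds with values here, the one measured step close to this change is a 1.7-fold lower number from compound 2 to compound 3 (0.23 log units; within the scatter) and it only exchanges thiophen-2-yl for thiophen-3-yl. Within the data shown here, no measured step exchanges a thiophene for a furan with the rest of the structure unchanged. Compound 1 does carry furan-2-yl and gives 4900 nM but its hydroxyphenyl group is not that of compound 4. So in this assay no step beyond the scatter is expected, with a slight lean towards a lower number. The estimate amounts to a 1.2-fold lower number from compound 3 to compound 4 (0.09 log units; within the scatter) as an expected step. For compound 4 the expected value is 9500 nM with an estimated range from 4000 nM to 22000 nM as the likely span.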

Compound 4, half-maximal inhibitory concentration: 34900 nM
Beside the measured number, compound 4's estimate is 3.7-fold (0.57 log units) below it; measured number outside the range, above it.
By their numbers in this assay, from the lowest: compound 1; then compounds 3, 2 and 4 (each within the scatter of the next, the first and the last beyond it).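

In this assay, the position next to the ring nitrogen now shows a change of the five-membered ring that goes beyond the scatter: furan-2-yl in place of thiophen-3-yl gives a 3.0-fold higher number from compound 3 to compound 4 (0.47 log units; beyond the scatter). Furan-2-yl in place of thiophen-2-yl, however, gives a 1.8-fold higher number from compound 2 to compound 4 (0.25 log units; within the scatter), so the reading of this exchange depends on which thiophene it replaces, while with furan-2-yl held constant, 3-hydroxyphenyl in place of 2-hydroxyphenyl gives a 7.1-fold higher number from compound 1 to compound 4 (0.85 log units; beyond the scatter), a change away from this position. Nothing available here accounts for these differences.

From the compounds shown here alone, whether the thiophenes and furan-2-yl would compare in the same way alongside the 2-hydroxyphenyl group stays open. So does how this position would respond to an amine or a longer chain in place of the five-membered ring.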